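This account rests on a few compounds, and the source may have more. Where it says the series, first, only, none or still open, it means among the compounds named here.

Three compounds sharing one core were tested in a functional assay on CHO cells with adenosine receptor A1 (Homo sapiens) as the target, read by cAMP accumulation and immunoassay, with a stated time of 6 min, tested at 10 uM; a higher number here means a weaker effect of the compound at the concentration tested, a lower number a stronger effect. Compound 1 `Nc1scc(CN2CCN(c3ccccc3C(F)(F)F)CC2)c1C(=O)c1ccc(Cl)cc1` gives -60%. Compound 2 `Nc1scc(CN2CCN(c3cc(F)cc(F)c3)CC2)c1C(=O)c1ccc(Cl)cc1` gives -79%, and compound 3 `Nc1scc(CN2CCN(c3ccc(F)c(Cl)c3)CC2)c1C(=O)c1ccc(Cl)cc1` gives -78%. Among these three numbers compound 1 stands highest, which means the weakest effect of the three at the tested concentration. The gap between compound 2 and compound 3 is a number 1 percentage points higher from compound 2 to compound 3 (within the scatter), so these two cannot be told apart.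

Compound 4 `Nc1scc(CN2CCN(c3cccc(Cl)c3)CC2)c1C(=O)c1ccc(Cl)cc1` has not yet been measured. Compared with compound 1 it carries 3-chlorophenyl in place of 2-(trifluoromethyl)phenyl on an amine nitrogen in a ring. Two measured steps start from compound 1 and likewise exchange the 2-(trifluoromethyl)phenyl for another phenyl ring: the step to compound 2 is a number 19 percentage points lower from compound 1 to compound 2 (beyond the scatter) and the step to compound 3 is a number 18 percentage points lower from compound 1 to compound 3 (beyond the scatter). Both move toward a stronger effect by a modest amount. A step of similar size and direction is therefore expected for compound 4, namely a number 16 percentage points lower from compound 1 to compound 4 (beyond the scatter). Compound 4 is estimated at -76%, with a likely range from -90% to -60%.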

Compound 4, a percentage reported as activity, at one concentration (the size of the read-out at that concentration, not a potency): -77%
Compound 4: middle estimate off by 1 percentage points, on the high side; low and high end bracket the measured number.
By their numbers in this assay, from the lowest: compounds 2, 3 and 4 (each within the scatter of the next); then compound 1.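

In this assay, 3-chlorophenyl in place of 2-(trifluoromethyl)phenyl on the amine nitrogen in the ring gives a number 17 percentage points lower from compound 1 to compound 4 (beyond the scatter), so a ring with a single chlorine and no fluorine also falls in the same range as the two fluorine-bearing rings. Hydrogen in place of fluoro gives a number 1 percentage points higher from compound 3 to compound 4 (within the scatter), and exchanging the 3,5-difluorophenyl gives a number 2 percentage points higher from compound 2 to compound 4 (within the scatter), so compounds 2, 3 and 4 cannot be told apart and fluorine shows no measurable contribution in this set. Nothing available explains why these three rings differ from the 2-(trifluoromethyl)phenyl ring.

Going by these compounds, whether any substituent on this phenyl ring is needed at all remains open. A plain phenyl ring, or one carrying a methoxy group or an amine, could settle that question.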